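Furan-2-yl in place of thiophen-2-yl on the shared core

The source may report more compounds than this note shows. Statements on the series, on what has been measured and on what is new or still open speak of the compounds shown alone.

Of the compounds shown here, two on the shared core have numbers so far in an ADME assay on A549 cells (Homo sapiens) for cytotoxicity, read by MTT assay, with a stated time of 72 h; on this read-out lower numbers stand for stronger inhibition and higher numbers for weaker inhibition. Compound 1 `O=C1Nc2ccc(Br)cc2C1=Cc1cccnc1` gives 31400 nM. Compound 2 `O=C1Nc2ccc(Br)cc2C1=Cc1cccs1` gives 427000 nM, the higher of the two numbers and so the weaker inhibition. Among the measured compounds shown here, the only measured step is a 14-fold higher number from compound 1 to compound 2 (1.13 log units; beyond the scatter), large and beyond the scatter, with thiophen-2-yl in place of pyridin-3-yl.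

Compound 3 `O=C1Nc2ccc(Br)cc2C1=Cc1ccco1` keeps the shared core and changes only the group on the double-bonded chain carbon bound to a double-bonded ring carbon: furan-2-yl in place of thiophen-2-yl, (furan-2-yl in place of thiophen-2-yl on a double-bonded chain carbon bound to a double-bonded ring carbon). For the measured compounds named here, no measured step covers this exchange directly. Here one five-membered aromatic ring with 1 hetero atom replaces another, so a smaller move than a 14-fold higher number from compound 1 to compound 2 (1.13 log units; beyond the scatter) is expected. Going by the values given here, a lean towards a lower number is also expected, as compound 2 at 427000 nM stands at the high end of the numbers so far.

The expected step is a 2.1-fold lower number from compound 2 to compound 3 (0.33 log units; beyond the scatter). Compound 3 is estimated at 200000 nM, with an expected range from 50000 nM to 500000 nM.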

Compound 3, half-maximal inhibitory concentration: 449000 nM
Beside the measured number, compound 3's estimate is 2.2-fold (0.35 log units) below it; the measured number falls inside the stated range.
By their numbers in this assay, from the lowest: compound 1; then compounds 2 and 3 (each within the scatter of the next).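

In this assay furan-2-yl in place of thiophen-2-yl on a double-bonded chain carbon bound to a double-bonded ring carbon gives a 1.1-fold higher number from compound 2 to compound 3 (0.02 log units; within the scatter), so exchanging one five-membered aromatic ring with 1 hetero atom for another, with oxygen entering and sulfur leaving, gives no readable separation at this position. The comparison with pyridin-3-yl now rests on two groups rather than one: furan-2-yl in place of pyridin-3-yl gives a 14-fold higher number from compound 1 to compound 3 (1.16 log units; beyond the scatter), which places compound 2 and compound 3 on the same side of compound 1, with the higher numbers and so the weaker inhibition. Nothing on hand accounts for either the large step from pyridin-3-yl or the absence of a readable step between the two five-membered rings.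

Still open, as far as these compounds go, is whether a phenyl or a pyridin-4-yl group at this place would fall with compound 1 or with compound 2 and compound 3. From the compounds shown here alone, it is also open whether the same order of groups would hold on a core carrying a chloro or methoxy group in place of the bromo group.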